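Chloro replaces hydrogen on the aryl ring of compound 1

The compounds below may be only part of what the source reports. "The series", "measured", "known", "first", "only" and "open" are said of these compounds alone.

Measured compounds:
compound 1, `CC1=CC[C@@H]([C@@](C)(O)CCCC(C)(C)NC(=S)N/N=C\c2ccccc2)CC1`, gives 7720 nM in a functional assay on MCF7 cells (Homo sapiens) for cytotoxicity, read by sulforhodamine B assay; a higher number here means a weaker inhibitor of growth, a lower number a stronger inhibitor of growth.
compound 2, `CC1=CC[C@@H]([C@@](C)(O)CCCC(C)(C)NC(=S)N/N=C\c2ccc([N+](=O)[O-])cc2)CC1`, gives 17700 nM in this assay.

Among the compounds with values here, compound 1 has the lowest number of the two measured in this assay, so it is the stronger growth inhibitor; the only neighbour is compound 2, which stands a 2.3-fold higher number from compound 1 to compound 2 (0.36 log units; beyond the scatter) away.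

Compound 3, `CC1=CC[C@@H]([C@@](C)(O)CCCC(C)(C)NC(=S)N/N=C\c2ccc(Cl)cc2)CC1`, differs from compound 1 in one place: chloro in place of hydrogen on an aromatic carbon

Within the data shown here, the only measured step that bears on this is the one from compound 1 to compound 2, in which a nitro group enters at an aromatic carbon and the number rises by a 2.3-fold higher number from compound 1 to compound 2 (0.36 log units; beyond the scatter), a modest change. A chloro at the same kind of carbon is a different group, so the nitro step is only a loose guide. For compound 3 the expected step is a 1.2-fold higher number from compound 1 to compound 3 (0.09 log units; within the scatter), which may well lie within the scatter. The estimated value for compound 3 is therefore 9500 nM, with a range from 4000 nM to 22000 nM.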

Compound 3, concentration for 50% growth inhibition: 6890 nM
Compound 3: the middle estimate sits 1.4-fold (0.14 log units) above what was measured; low and high end bracket the measured number.
By their numbers in this assay, from the lowest: compounds 3 and 1 (each within the scatter of the next); then compound 2.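

Placing chloro on this aromatic carbon, para to a large group, leaves the reading in this assay within the scatter (a 1.1-fold lower number from compound 1 to compound 3 (0.05 log units; within the scatter)), so going from phenyl to 4-chlorophenyl shows no clear effect on growth inhibition. The earlier nitro step therefore does not hold for every group at this carbon, and exchanging nitro for chloro shifts the reading beyond the scatter (a 2.6-fold lower number from compound 2 to compound 3 (0.41 log units; beyond the scatter)). Nothing measured here accounts for the difference between chloro and nitro.

From the compounds shown here alone, it remains open where other groups on this carbon would fall, such as an amine, a methoxy group or a carboxylic acid, and whether they would read closer to chloro or to nitro. Also open, going by these compounds, is whether fluoro or bromo would match chloro here.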